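The source may hold more compounds than are shown below. What is called first, only, known or untested is meant among the compounds shown, and "the series" means these compounds.

Compound 1 `Fc1ccccc1N1CCN(Cc2nc3ccccc3[nH]2)CC1` and compound 2 `CSc1ccccc1N1CCN(Cc2nc3ccccc3[nH]2)CC1` share one core and differ only in the group on the aromatic ring attached to the ring nitrogen. Within the data shown here, in an assay on HEK293 cells with D(4) dopamine receptor (Homo sapiens) as the target, read by FLIPR (a higher number here means that more compound is needed for the effect, a lower number that less compound is needed), compound 1 gives 14.7 nM, while compound 2 gives 86 nM, the higher of the two numbers; the single step, a 5.9-fold higher number from compound 1 to compound 2 (0.77 log units; beyond the scatter), lies beyond the scatter. Compound 3 `Cc1cccc(N2CCN(Cc3nc4ccccc4[nH]3)CC2)n1` has not yet been measured. Among the measured compounds shown here, the change is 6-methylpyridin-2-yl in place of 2-(methylsulfanyl)phenyl on an amine nitrogen in a ring, an exchange of the whole aromatic ring rather than one substituent on it, so no measured step matches it directly; the only step in hand shows that a swap at this position can move the number by a modest amount. The expected step of a 2.2-fold lower number from compound 2 to compound 3 (0.33 log units; beyond the scatter) is a slight fall, with wide uncertainty. Compound 3 is therefore estimated at 40 nM, with a plausible range from 10 nM to 160 nM.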

Compound 3, half-maximal effective concentration: 36.2 nM
For compound 3 the middle estimate is 1.1-fold (0.04 log units) above the measured one, within the range that was stated.
By their numbers in this assay, from the lowest: compound 1; then compound 3; then compound 2.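

Exchanging the whole aromatic ring, not just one substituent on it, still leaves a measurable effect in this assay, and 6-methylpyridin-2-yl places compound 3 between the two earlier compounds. It improves on 2-(methylsulfanyl)phenyl (a 2.4-fold lower number from compound 2 to compound 3 (0.38 log units; beyond the scatter)) but falls short of 2-fluorophenyl (a 2.5-fold higher number from compound 1 to compound 3 (0.39 log units; beyond the scatter)), so a ring with a hetero atom can stand at this position, though here it does not match the best number shown. No supporting data bear on why the number moves this way.

On these data alone, the ring nitrogen and the methyl group enter together, so their separate shares in the step remain unknown. Also open, as far as these compounds go, is how the number would respond to a methoxy group or an amine on the aromatic ring.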